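Removing a Trifluoromethyl Group in a Cytotoxicity Series

The source may report more compounds than this note shows. Statements on the series, on what has been measured and on what is new or still open speak of the compounds shown alone.

Measured compounds in a functional assay on L6 cells (Rattus norvegicus) for cytotoxicity; on this read-out higher numbers stand for weaker inhibition and lower numbers for stronger inhibition:
- Compound 1 `N=C(NO)c1ccc(-c2ccc(-c3ccc(/C(N)=N\O)cc3)cc2)cc1` gives only a limit, > 211000 nM.
- Compound 2 `CONC(=N)c1ccc(-c2ccc(-c3ccc(C(=N)NOC)cc3)c(C(F)(F)F)c2)cc1` gives 42200 nM.
- Compound 3 `N=C(NO)c1ccc(-c2ccc(-c3ccc(/C(N)=N\O)cc3)cc2C(F)(F)F)cc1` gives 13300000 nM.

Compound 1 and compound 3 share one core; how the core of compound 2 differs from that of compound 3 is not broken down here. Going from compound 3 to compound 1 the change is hydrogen in place of trifluoromethyl on an aromatic carbon. The size of that step, a step that the limit leaves unreadable from compound 3 to compound 1, cannot be read, since the value of compound 1 is the limit of > 211000 nM in this assay, at which 1 of the 3 values shown sits. Among the two plain numbers, compound 2 stands lowest, and compound 3 sits far higher, well beyond the usual scatter.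

Compound 4 `CONC(=N)c1ccc(-c2ccc(-c3ccc(C(=N)NOC)cc3)cc2)cc1` has not been measured. It differs from compound 2 by hydrogen in place of trifluoromethyl on an aromatic carbon, which is the same change as that from compound 3 to compound 1, at a place described in identical words. Among the compounds with values here, the one earlier example of this change gives no readable size, so there is no measured guide for its effect. Given that compound 2 gives 42200 nM in this assay, compound 4 is expected to stay in the same region, at an estimated 60000 nM, a step of a 1.4-fold higher number from compound 2 to compound 4 (0.15 log units; within the scatter). For compound 4 the expected range is wide, from 15000 nM to 300000 nM, and it may well turn out as a limit.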

Compound 4, half-maximal inhibitory concentration: 118000 nM
Beside the measured number, compound 4's estimate is 2.0-fold (0.29 log units) below it; measured number inside the range.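

In this assay, putting hydrogen in place of trifluoromethyl on the core of compound 2 gives a 2.8-fold higher number from compound 2 to compound 4 (0.45 log units; beyond the scatter); this modest step lies beyond the usual scatter and points to weaker inhibition without the trifluoromethyl group on this core. On the core of compound 1, the same change cannot be read, and compound 1 gives only a limit, not a number: the limit of > 211000 nM in this assay, at which 1 of the 4 values shown sits. The series therefore offers a single readable example of this change, which shows its size and direction on one core but does not show whether either carries over to the other, so the two cores can be neither called alike nor called different in their response.

The compounds shown leave open how other groups on the same aromatic carbon, such as a methyl, a chlorine or an amine, would compare with hydrogen and trifluoromethyl on either core. They also leave open whether a third core, for example one with a carboxylic acid or a nitrile in place of the end groups of compound 2, would respond to this change as the core of compound 2 does.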